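Aryl variation on the shared core: notes toward compound 3

A few compounds are considered here, and "the series" means these few. Any claim that something is new, unique, unknown or untested is made for them only; others in the source may bear on it.

compound 1 `COc1cc(-n2cnc3ccc(-c4cc(F)ccc4F)cc32)cc(OC)c1OC` — 6590 nM
compound 2 `COc1cc(-n2cnc3ccc(-c4cccc(C)c4)cc32)cc(OC)c1OC` — 1240 nM

Both were read in a functional assay on SGC-7901 cells (Homo sapiens) for antiproliferative activity, read by MTT assay, with a stated time of 72 h; on this read-out lower numbers stand for stronger inhibition and higher numbers for weaker inhibition; compound 1 gives 6590 nM and compound 2 gives 1240 nM. Among the measured compounds shown here, the single measured step is a 5.3-fold lower number from compound 1 to compound 2 (0.73 log units; beyond the scatter). On these two numbers compound 2 stands lowest, with compound 1 as its nearest neighbour at a gap beyond the scatter.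

Compound 3 `COc1cc(-n2cnc3ccc(-c4ccc(O)cc4)cc32)cc(OC)c1OC` differs from compound 2 in one place: 4-hydroxyphenyl in place of 3-methylphenyl on an aromatic carbon.

For the measured compounds named here, no measured step concerns a hydroxyl entering on an aromatic carbon. Going by the values given here, the only step available, a 5.3-fold lower number from compound 1 to compound 2 (0.73 log units; beyond the scatter), swaps two other groups at the same carbon and shows merely that exchanges there can move the number beyond the scatter. With nothing more to lean on, the expected step from compound 2 to compound 3 in this assay is small and of uncertain direction, a 1.6-fold higher number from compound 2 to compound 3 (0.21 log units; within the scatter). Compound 3 is estimated at 2000 nM, with a range from 600 nM to 7000 nM.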

Compound 3, half-maximal inhibitory concentration: > 10000 nM
Compound 3 was reported as a limit; the forecaster's own chance of this, stated with the estimate: 5%; middle value at least 5.0-fold (0.69 log units) from the limit.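

In this assay, compound 3 is reported only as a limit: the limit of > 10000 nM in this assay, at which 1 of the 3 values shown sits.

Among the compounds shown here, replacing 3-methylphenyl with 4-hydroxyphenyl gives an at least 8.0-fold higher number from compound 2 to compound 3 (0.90 log units; beyond the scatter), so this aromatic carbon also admits a change that moves the number upward, opposite in direction to the only earlier step. Against the 2,5-difluorophenyl group the exchange gives an at least 1.5-fold higher number from compound 1 to compound 3 (0.18 log units; that floor lies within the scatter), and with that floor inside the scatter, the limit does not separate the two compounds.

The compounds shown do not separate the entry of the hydroxyl from the change in where the phenyl ring carries its substituent. Going by these compounds, how an amine or a carboxylic acid in place of that hydroxyl would read remains open, as does the actual value of compound 3 beyond its limit.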